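Extending the chain at the core of compound 1 toward a pyrrolidine

The compounds below may be only part of what the source reports. "The series", "measured", "known", "first", "only" and "open" are said of these compounds alone.

Compound 1 `CCCCNc1nc(N)nc(C)c1C` is the weakest of the three compounds measured in an assay on HEK293 cells for agonist activity at Toll-like receptor 8 (Homo sapiens), read by spectrophotometry; on this read-out higher numbers stand for an effect only at larger amounts of compound and lower numbers for an effect already at smaller amounts: compound 1 gives 3280 nM, the highest number of the set. Compound 2 `CCCCCc1c(C)nc(N)nc1NCCCC` gives 1220 nM and compound 3 `CCCCNc1nc(N)nc(C)c1CCCn1cccn1` gives 1050 nM, so the step of a 2.7-fold lower number from compound 1 to compound 2 (0.43 log units; beyond the scatter) and the step of a 3.1-fold lower number from compound 1 to compound 3 (0.49 log units; beyond the scatter) both lower the number modestly but clearly. Between the two elaborated compounds the step of a 1.2-fold lower number from compound 2 to compound 3 (0.07 log units; within the scatter) is flat, so the choice of group at the end of the chain hardly matters there.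

Compound 4 `CCCCNc1nc(N)nc(C)c1CCCN1CCCC1` alters compound 1 in the same position: 2-(pyrrolidin-1-yl)ethyl in place of hydrogen on a saturated chain carbon bound to an aromatic carbon. The two steps that bear on it, from compound 1 to compound 2 and from compound 1 to compound 3, each added a chain of similar length at this saturated chain carbon bound to an aromatic carbon and each gave a modest drop. A step of comparable size in the same direction is therefore expected for compound 4, namely a 3.0-fold lower number from compound 1 to compound 4 (0.47 log units; beyond the scatter), with the 2-(pyrrolidin-1-yl)ethyl group behaving much like the butyl or the 2-(1H-pyrazol-1-yl)ethyl group. Compound 4 is accordingly estimated at 1100 nM, in a range from 400 nM to 3000 nM.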

Compound 4, half-maximal effective concentration: 110 nM
Beside the measured number, compound 4's estimate is 10-fold (1.00 log units) above it; measured number below the stated range.
By their numbers in this assay, from the lowest: compound 4; then compounds 3 and 2 (each within the scatter of the next); then compound 1.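

What compound 4 adds is that the group at the end of this chain can matter a great deal, not merely the presence of a chain on the saturated chain carbon bound to an aromatic carbon: in this assay the addition of 2-(pyrrolidin-1-yl)ethyl gives a 30-fold lower number from compound 1 to compound 4 (1.47 log units; beyond the scatter) and so goes well past the modest steps seen with the two earlier chains. The end group had looked unimportant when ethyl gave way to 1H-pyrazol-1-yl, with a 1.2-fold lower number from compound 2 to compound 3 (0.07 log units; within the scatter) as the result. That reading does not hold for pyrrolidin-1-yl, which gives a 9.5-fold lower number from compound 3 to compound 4 (0.98 log units; beyond the scatter) in place of 1H-pyrazol-1-yl and an 11-fold lower number from compound 2 to compound 4 (1.04 log units; beyond the scatter) in place of ethyl. No measurement is available to account for the difference between these end groups.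

The compounds shown leave open whether the lower number belongs to the pyrrolidine ring itself or would also come with a piperidine, a morpholine or an open-chain dimethylamino group at the same chain end. They also do not tell how a shorter or longer chain carrying the pyrrolidin-1-yl group would fare on the core of compound 1.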